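This account rests on a few compounds, and the source may have more. Where it says the series, first, only, none or still open, it means among the compounds named here.

Compound 1 `COc1nc(N)nc2c1c(-c1cccs1)cn2[C@@H]1O[C@H](CO)[C@@H](O)[C@H]1O` gives > 20000 nM, which is a limit of the assay and not a number.
Compound 2 `COc1nc(N)nc2c1c(-c1ccoc1)cn2[C@@H]1O[C@H](CO)[C@@H](O)[C@H]1O` gives > 20000 nM, likewise a limit.
Compound 3 `CSc1ncnc2c1c(-c1ccoc1)cn2[C@@H]1O[C@H](CO)[C@@H](O)[C@H]1O` gives 360 nM.

These three compounds were tested in a functional assay on HL-60 cells (Homo sapiens) for antiproliferative activity, read by XTT assay, with a stated time of 72 h; on this read-out lower numbers stand for stronger inhibition and higher numbers for weaker inhibition. For the measured compounds named here, compound 3 is the only one with a number. Compound 1 and compound 2 sit at the limit of > 20000 nM in this assay, at which 2 of the 3 values shown sit. Compound 2 and compound 3 differ in more than one place, and the difference between their two cores is not broken down here. Compound 1 differs from compound 2 by thiophen-2-yl in place of furan-3-yl on an aromatic carbon, and the step this made, a step that the two limits leave unreadable from compound 2 to compound 1, is not readable, as both values sit at the limit of > 20000 nM in this assay, at which 2 of the 3 values shown sit. Compound 4 `CSc1ncnc2c1c(-c1cccs1)cn2[C@@H]1O[C@H](CO)[C@@H](O)[C@H]1O`, not yet measured, differs from compound 3 by thiophen-2-yl in place of furan-3-yl on an aromatic carbon, the same change at the same place. Going by the values given here, the one measured example of this change gives no readable size, so the expectation for compound 4 rests on compound 3 alone, whose value 360 nM is the only number in hand. A small step is expected, a 1.1-fold higher number from compound 3 to compound 4 (0.05 log units; within the scatter). Compound 4 is estimated at 400 nM, between 120 nM and 1500 nM.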

Compound 4, half-maximal inhibitory concentration: 1130 nM
Beside the measured number, compound 4's estimate is 2.8-fold (0.45 log units) below it; low and high end bracket the measured number.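

In this assay, thiophen-2-yl in place of furan-3-yl on the core of compound 3 gives a 3.1-fold higher number from compound 3 to compound 4 (0.50 log units; beyond the scatter), so on this core the change costs a modest amount of activity, though the compound keeps a measured value. On the core of compound 2 the same change cannot be read, and this single readable step therefore shows nothing about whether its size or direction carries from one core to the other. Neither compound 1 nor compound 2 gives a number, and the comparison between them stays closed: the limit of > 20000 nM in this assay, at which 2 of the 4 values shown sit.

The compounds shown leave open how a phenyl ring, or an amine, would read at this same place on the core of compound 3. They also leave open which part of the difference between the core of compound 2 and the core of compound 3 separates the limits from the measured values, and whether the change would repeat on a further core where both partners give numbers.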